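Taking one methoxy away from compound 2

The compounds below may be only part of what the source reports. "The series", "measured", "known", "first", "only" and "open" are said of these compounds alone.

In an ADME assay for pharmacokinetics, at pH 7.4 (on this read-out lower numbers stand for a shorter-lived compound and higher numbers for a longer-lived compound), compound 1 (`COc1ccnc(C[S+]([O-])c2nc3cc(OC(F)(F)C(F)F)ccc3[nH]2)c1OC`) gives 160 h and compound 2 (`COc1cnc(C[S+]([O-])c2nc3cc(OC(F)(F)C(F)F)ccc3[nH]2)cc1OC`) gives 140 h and so stands within the scatter of compound 1. Compound 3 (`COc1ccnc(C[S+]([O-])c2nc3cc(OC(F)(F)C(F)F)ccc3[nH]2)c1`) has hydrogen in place of methoxy on an aromatic carbon. Among the compounds with values here, no measured pair shows this change on its own, so the guide is thin, and no shift beyond the scatter is expected. The expected step is a 1.1-fold lower number from compound 2 to compound 3 (0.03 log units; within the scatter) and would stay within the scatter. For compound 3 the estimated half-life is 130 h with an expected range from 70 h to 240 h in repeated measurements.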

Compound 3, half-life: 63 h
For compound 3 the middle estimate is 2.1-fold (0.31 log units) above the measured one; the measured number lies below the stated range.
By their numbers in this assay, from the lowest: compound 3; then compounds 2 and 1 (each within the scatter of the next).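

In this assay, the methoxy on this aromatic carbon turns out to matter: hydrogen in its place gives a 2.2-fold lower number from compound 2 to compound 3 (0.35 log units; beyond the scatter) and, measured against the other compound with two methoxy groups, a 2.5-fold lower number from compound 1 to compound 3 (0.40 log units; beyond the scatter). Both steps lie beyond the scatter, so compound 3, with a single methoxy on this ring, has the shortest half-life of the three. Nothing available explains why the half-life falls with this change. Still open, as far as these compounds go, is whether methoxy itself is needed here, or whether an ethoxy, a chlorine or an amine on this carbon would hold the half-life equally well.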